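Thiophene sulfonamide in place of the imidazole sulfonamide

The source may hold more compounds than are shown below. What is called first, only, known or untested is meant among the compounds shown, and "the series" means these compounds.

Among the measured compounds shown here, compound 1 `CCN1CCN(c2cccc3c2CN([C@H](CCCNS(=O)(=O)c2c[nH]cn2)c2ccc(OC)c(OC)c2)C3=O)CC1` is the one compound here with a stated number: in an assay on RMS13 cells for displacement of a labelled ligand from Urotensin-2 receptor (Homo sapiens), read by scintillation proximity assay (a lower number here means a stronger inhibitor, a higher number a weaker inhibitor), compound 1 gives 25 nM. Compound 2 `COc1ccc([C@@H](CCCN(C)S(=O)(=O)c2cccs2)N2Cc3c(cccc3N3CCN(C)CC3)C2=O)cc1OC` returns only a limit, < 6 nM, in this assay. That limit is the limit of < 6 nM in this assay, at which 1 of the 2 values shown sits. Compound 3 `CCN1CCN(c2cccc3c2CN([C@H](CCCN(C)S(=O)(=O)c2cccs2)c2ccc(OC)c(OC)c2)C3=O)CC1` carries methyl((thiophen-2-yl)sulfonyl)amino in place of ((1H-imidazol-4-yl)sulfonyl)amino on a saturated chain carbon, four bonds along the chain from an amide-type nitrogen in a ring and an aromatic carbon, the same sulfonamide arrangement that compound 2 holds. For the measured compounds named here, no measured step covers this change on its own. Compound 3 is expected to move toward the limit, a step of a 4.2-fold lower number from compound 1 to compound 3 (0.62 log units; beyond the scatter) in this assay. Compound 3 is estimated at 6 nM, within a range of 2 nM to 18 nM.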

Compound 3, inhibition constant: < 5 nM
Compound 3: only a limit was reported; the forecaster's own chance of this, stated with the estimate: 45%; middle value at least 1.2-fold (0.07 log units) from the limit.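

In this assay, among the compounds shown here, methyl((thiophen-2-yl)sulfonyl)amino in place of ((1H-imidazol-4-yl)sulfonyl)amino on the core of compound 1 gives an at least 5.0-fold lower number from compound 1 to compound 3 (0.69 log units; beyond the scatter), the only readable single-place comparison at this position. Compound 3 is reported only as a limit, < 5 nM. The step between compound 2 and compound 3 cannot be read.

From the compounds shown here alone, the change swaps the ring and adds the nitrogen methyl together, so the share of each stays open. ((Thiophen-2-yl)sulfonyl)amino, without the methyl, on the same chain would separate the two.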